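The source may report more compounds than this note shows. Statements on the series, on what has been measured and on what is new or still open speak of the compounds shown alone.

Working notes on the series

In an assay on isolated protein for inhibition of protein deacetylase HDAC6 (Homo sapiens), read by fluorescence, with stated times of 5 min and 60 min (on this read-out higher numbers stand for weaker inhibition and lower numbers for stronger inhibition), compound 1 `O=C(CCC1C(=O)N(c2ccc(Cl)cc2)C(=O)N1Cc1ccc(Br)cc1)Nc1ccc(C(=O)NO)cc1` gives 9.7 nM, the second highest of the three numbers recorded. Compound 3 `CCCN1C(=O)N(c2ccc(Cl)cc2)C(=O)C1CCC(=O)Nc1ccc(C(=O)NO)cc1` gives 12.6 nM in this assay, and the step of a 1.3-fold higher number from compound 1 to compound 3 (0.11 log units; within the scatter) is within the scatter. Compound 2 `Cc1ccc(CN2C(=O)N(c3ccc(Cl)cc3)C(=O)C2CCC(=O)Nc2ccc(C(=O)NO)cc2)cc1` gives 4.4 nM, reached through the step of a 2.2-fold lower number from compound 1 to compound 2 (0.34 log units; beyond the scatter); the step of a 2.9-fold higher number from compound 2 to compound 3 (0.46 log units; beyond the scatter) is the largest gap seen so far and is still only modest.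

Compound 4 `O=C(CCC1C(=O)N(Cc2ccccc2)C(=O)N1Cc1ccc(Br)cc1)Nc1ccc(C(=O)NO)cc1` differs from compound 1 by one change: benzyl in place of 4-chlorophenyl on an amide-type nitrogen in a ring. Within the data shown here, no measured step touches the group on that ring nitrogen; the steps seen concern the aromatic bromo against methyl and the substituent on the saturated chain carbon. They therefore bear on the new change only indirectly, showing that single exchanges of comparable size elsewhere on the shared core moved this assay by modest amounts or stayed within the scatter. On that basis the expected step of a 1.2-fold higher number from compound 1 to compound 4 (0.09 log units; within the scatter) is within the scatter, with no direction favoured. Compound 4 is estimated at 12 nM, within a range of 4.5 nM to 32 nM.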

Compound 4, half-maximal inhibitory concentration: 9.8 nM
Compound 4: the middle estimate sits 1.2-fold (0.09 log units) above what was measured, and the stated range covers the measured number.
By their numbers in this assay, from the lowest: compound 2; then compounds 1, 4 and 3 (each within the scatter of the next).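

Among these compounds, this is the first measured exchange on the amide-type nitrogen in a ring, and in this assay benzyl in place of 4-chlorophenyl gives the step of a 1.0-fold higher number from compound 1 to compound 4 (0.00 log units; within the scatter). Both groups have the same heavy-atom count and one six-membered aromatic ring of carbon only, so for this pair, with the 4-bromobenzyl group held constant, losing the chlorine and changing how the aromatic ring is attached leave the read-out within the scatter. Nothing measured here accounts for this flat result.

As far as these compounds go, it remains open whether the same holds for a group on that nitrogen with no aromatic ring, such as cyclohexyl, or for one carrying an amine or a carboxylic acid. Also open, from the compounds shown here alone, is whether benzyl at this position behaves alike when the 4-methylbenzyl group of compound 2 replaces the 4-bromobenzyl group.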